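This account rests on a few compounds, and the source may have more. Where it says the series, first, only, none or still open, it means among the compounds named here.

Of the compounds shown here, three here share one core and have been measured; a fourth awaits measurement. Compound 1 `COc1cc(F)c(NC(=O)c2ccncc2OC)cc1Nc1nccc(-c2cn(C)c3ccccc23)n1` gives 4120 nM in a functional assay on NCI-H1975 cells (Homo sapiens) for antiproliferative activity, read by MTT assay, with a stated time of 72 h; on this read-out higher numbers stand for weaker inhibition and lower numbers for stronger inhibition. Compound 2 `COc1cc(F)c(NC(=O)c2nccn2C)cc1Nc1nccc(-c2cn(C)c3ccccc23)n1` gives 10600 nM in this assay, and the step of a 2.6-fold higher number from compound 1 to compound 2 (0.41 log units; beyond the scatter) shows what one swap of the ring on the carbonyl carbon did. Compound 3 `COc1cc(N(C)CCN(C)C)c(NC(=O)c2ccncc2OC)cc1Nc1nccc(-c2cn(C)c3ccccc23)n1` gives 1010 nM in this assay, the lowest number of the three, reached through the step of a 4.1-fold lower number from compound 1 to compound 3 (0.61 log units; beyond the scatter). Compound 4 `COc1cc(N(C)CCN(C)C)c(NC(=O)c2ccncn2)cc1Nc1nccc(-c2cn(C)c3ccccc23)n1` differs from compound 3 in one place: pyrimidin-4-yl in place of 3-methoxypyridin-4-yl on a carbonyl carbon. For the measured compounds named here, the only measured step that touches this position is a 2.6-fold higher number from compound 1 to compound 2 (0.41 log units; beyond the scatter), where a different ring replaced the same leaving group; a modest weakening is therefore the likeliest outcome, because a 2.6-fold higher number from compound 1 to compound 2 (0.41 log units; beyond the scatter) stayed modest. The step is expected to read a 2.0-fold higher number from compound 3 to compound 4 (0.30 log units; within the scatter), upward and small enough that it may sit near the edge of the scatter. Compound 4 is expected to give 2000 nM, with a plausible range from 700 nM to 6000 nM.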

Compound 4, half-maximal inhibitory concentration: 1560 nM
Compound 4: middle estimate off by 1.3-fold (0.11 log units), on the high side, and the stated range covers the measured number.
By their numbers in this assay, from the lowest: compounds 3 and 4 (each within the scatter of the next); then compound 1; then compound 2.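

In this assay, replacing 3-methoxypyridin-4-yl with pyrimidin-4-yl on the carbonyl carbon gives a 1.5-fold higher number from compound 3 to compound 4 (0.19 log units; within the scatter), so this pair cannot be told apart, even though the entering ring has no methoxy group and carries a second ring nitrogen. For the compounds shown here, the only earlier change at this position, a 2.6-fold higher number from compound 1 to compound 2 (0.41 log units; beyond the scatter), lay beyond the scatter, so the new step shows that not every ring swap here moves the number measurably, although the two steps involve different rings and sit on compounds that differ elsewhere. No measurement offers a reason why compound 3 and compound 4 read alike.

The compounds shown leave open whether pyrimidin-4-yl would read the same with fluoro in place of the (2-(dimethylamino)ethyl)(methyl)amino group. They also leave open what a plain phenyl ring, or a ring bearing a carboxylic acid, would do on this carbonyl carbon.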